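Chain-arm variation on a shared amide series

A few compounds are considered here, and "the series" means these few. Any claim that something is new, unique, unknown or untested is made for them only; others in the source may bear on it.

Three compounds carry the same core and differ in the acyl arm of the amide. Compound 1 `COc1cccc(CCCC(=O)Nc2nc3ccccc3c(=O)s2)c1` gives 382 nM in an assay on CHO cells for displacement of a labelled ligand from adenosine receptor A3 (Homo sapiens), read by scintillation counting, with a stated time of 60 min; on this read-out higher numbers stand for weaker inhibition and lower numbers for stronger inhibition. Compound 2 `O=C(CCCc1ccccc1)Nc1nc2cc(Cl)ccc2c(=O)s1` gives 91.6 nM in this assay. Compound 3 `O=C(CCc1ccccc1)Nc1nc2ccccc2c(=O)s1` gives 390 nM in this assay, the highest of the three numbers; its nearest neighbour is compound 1, a gap within the usual scatter, and its furthest is compound 2, a gap beyond the scatter. Within the data shown here, no pair of these three differs in one place only, so none of the gaps can be read as a single step.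

Compound 4 `O=C(CCCc1cccc(Cl)c1)Nc1nc2ccccc2c(=O)s1` has not yet been measured. Against compound 3 the change is 3-chlorobenzyl in place of phenyl on a saturated chain carbon, two bonds along the chain from a carbonyl carbon. The arm grows by one chain carbon and gains a chlorine on the ring. Compound 1 shows that a longer arm bearing a ring substituent can sit close to compound 3, while compound 2 shows a lower number with a longer arm and a chlorine placed elsewhere. On this basis the step of a 1.6-fold lower number from compound 3 to compound 4 (0.19 log units; within the scatter) is expected to be small, toward a lower number, and may fall within the scatter. Compound 4 is therefore estimated at 250 nM, with a range from 80 nM to 800 nM.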

Compound 4, inhibition constant: > 1000 nM
Compound 4 was reported as a limit; the forecaster's own chance of this, stated with the estimate: 2%; middle value at least 4.0-fold (0.60 log units) away from the limit.
By their numbers in this assay, from the lowest: compound 2; then compounds 1 and 3 (each within the scatter of the next). At a limit, above all of these: compound 4.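

These three sentences hold what compound 4 adds. Compound 4 stands in this assay at a limit and not at a number: the limit of > 1000 nM in this assay, at which 1 of the 4 values shown sits. Setting 3-chlorobenzyl in place of phenyl on a saturated chain carbon, two bonds along the chain from a carbonyl carbon, gives an at least 2.5-fold higher number from compound 3 to compound 4 (0.40 log units; beyond the scatter), the first reading of a single change at this place in the arm. Chloro in place of methoxy on an aromatic carbon gives an at least 2.6-fold higher number from compound 1 to compound 4 (0.41 log units; beyond the scatter), so with the arm length held the same, the identity of the ring substituent separates two compounds beyond the scatter, which no earlier pair could show.

The compounds shown leave open how much of the first step belongs to the added chain carbon and how much to the chlorine, and a plain phenyl on the longer chain over the unsubstituted shared core would divide the two. Also open, on these data alone, is how a methyl, a hydroxyl or an amine would read in place of the chloro or methoxy on that same aromatic carbon.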